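Carbonyl groups in place of phenethylsulfonyl on the ring amine

The source may hold more compounds than are shown below. What is called first, only, known or untested is meant among the compounds shown, and "the series" means these compounds.

Compound 1 `COc1ccc(-c2cn3cc(C4=CCN(S(=O)(=O)CCc5ccccc5)CC4)ccc3n2)cc1OC` carries a phenethylsulfonyl on an amine nitrogen in a ring; in a functional assay on B16-F10 cells (Mus musculus) for antiproliferative activity, read by MTT assay, with a stated time of 48 h (on this read-out higher numbers stand for weaker inhibition and lower numbers for stronger inhibition), compound 1 gives 8080 nM. Among the three measured numbers this is the second highest, with compound 3 the nearest and compound 2 the furthest, and both gaps are within the scatter. Compound 2 `COc1ccc(-c2cn3cc(C4=CCN(C(=O)C5CCCCC5)CC4)ccc3n2)cc1OC` gives 10900 nM in this assay, and compound 3 `COc1ccc(-c2cn3cc(C4=CCN(C(=O)C(C)(C)C)CC4)ccc3n2)cc1OC` gives 7100 nM. The steps are small: a 1.3-fold higher number from compound 1 to compound 2 (0.13 log units; within the scatter); a 1.1-fold lower number from compound 1 to compound 3 (0.06 log units; within the scatter); a 1.5-fold lower number from compound 2 to compound 3 (0.19 log units; within the scatter). So far, exchanging the phenethylsulfonyl for a carbonyl-bearing group, whether cyclohexylcarbonyl or (tert-butyl)carbonyl, has left the read-out essentially unchanged.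

Compound 4 `COc1ccc(-c2cn3cc(C4=CCN(C(=O)c5cccs5)CC4)ccc3n2)cc1OC` continues this line: (thiophen-2-yl)carbonyl in place of phenethylsulfonyl on an amine nitrogen in a ring. The two steps that bear on it are the ones from compound 1 to compound 2 and from compound 1 to compound 3, in which a carbonyl group likewise replaced the phenethylsulfonyl; both stayed within the scatter. On these data alone, no case with an aromatic ring on the carbonyl carbon has been measured, so the aromatic character of the entering group is untested here. On the evidence available, compound 4 is expected to show no step beyond the scatter, a 1.0-fold lower number from compound 1 to compound 4 (0.00 log units; within the scatter). The estimate for compound 4 in this assay is 8000 nM, with a range from 3500 nM to 18000 nM.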

Compound 4, half-maximal inhibitory concentration: 19500 nM
Compound 4: the middle estimate sits 2.4-fold (0.39 log units) below what was measured, outside the stated range (above it).
By their numbers in this assay, from the lowest: compounds 3, 1, 2 and 4 (each within the scatter of the next, the first and the last beyond it).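

Going by these compounds alone, at the amine nitrogen in the ring, carbonyl groups are no longer interchangeable with phenethylsulfonyl in this assay: (thiophen-2-yl)carbonyl gives a 2.4-fold higher number from compound 1 to compound 4 (0.38 log units; beyond the scatter) and is the first replacement there to leave the scatter, though only modestly. On the carbonyl carbon, thiophen-2-yl in place of tert-butyl gives a 2.7-fold higher number from compound 3 to compound 4 (0.44 log units; beyond the scatter) and so also lies beyond the scatter, while thiophen-2-yl in place of cyclohexyl gives a 1.8-fold higher number from compound 2 to compound 4 (0.25 log units; within the scatter) and stays within it, which means that the group on the carbonyl carbon can shift the read-out but that these two groups are not told apart. No measurement is available that would explain this difference in the read-out.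

Still open, on these data alone, is whether the step belongs to thiophen-2-yl itself or to any aromatic ring on the carbonyl carbon, which a phenyl or furan-2-yl group there would help to settle. Also open, as far as these compounds go, is how much the read-out depends on the carbonyl link itself, a point that a thiophen-2-ylsulfonyl group on the same ring nitrogen would address.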